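Substituent on the saturated ring carbon: methanesulfonamido analogue

The source may hold more compounds than are shown below. What is called first, only, known or untested is meant among the compounds shown, and "the series" means these compounds.

Compound 1 `COc1cc(COc2cc(N)c(Cl)cc2C(=O)CCCCN2CCC(C)CC2)cc(OC)c1` carries a methyl group on the saturated ring carbon of its six-membered non-aromatic ring; in a functional assay for antagonist activity at 5-hydroxytryptamine receptor 4 (Rattus norvegicus) (on this read-out lower numbers stand for lower potency and higher numbers for higher potency (the scale is a negative logarithm)), compound 1 gives 8.3. Among the three measured numbers compound 1 stands second highest, nearest to compound 3 `COc1cc(COc2cc(N)c(Cl)cc2C(=O)CCCCN2CCC(NC(N)=O)CC2)cc(OC)c1`, which gives 8.5 in this assay, and furthest from compound 2 `COc1cc(COc2cc(N)c(Cl)cc2C(=O)CCCCN2CCC(c3ccccc3)CC2)cc(OC)c1`, which gives 7.7. The measured steps read a number 0.20 log units higher from compound 1 to compound 3 (within the scatter), a number 0.60 log units lower from compound 1 to compound 2 (beyond the scatter) and a number 0.80 log units higher from compound 2 to compound 3 (beyond the scatter).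

Compound 4 `COc1cc(COc2cc(N)c(Cl)cc2C(=O)CCCCN2CCC(NS(C)(=O)=O)CC2)cc(OC)c1` differs from compound 1 in one place: methanesulfonamido in place of methyl on a saturated ring carbon. The step that bears most on this change is the one that placed ureido on the same carbon, a number 0.20 log units higher from compound 1 to compound 3 (within the scatter), which stayed within the scatter; the phenyl step, a number 0.60 log units lower from compound 1 to compound 2 (beyond the scatter), went the other way and beyond it. For methanesulfonamido the expectation is therefore no step beyond the scatter in this assay, a number 0.10 log units higher from compound 1 to compound 4 (within the scatter). Compound 4 is expected to give 8.4 in this assay, with a range from 7.9 to 8.9.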

Compound 4, negative logarithm of the antagonist equilibrium constant: 8.4
Compound 4: the middle estimate sits on the measured number at the digits printed; low and high end bracket the measured number.
By their numbers in this assay, from the lowest: compound 2; then compounds 1, 4 and 3 (each within the scatter of the next).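

In this assay, methanesulfonamido on the saturated ring carbon is a second group, after ureido, that leaves the number within the scatter of methyl (a number 0.10 log units higher from compound 1 to compound 4 (within the scatter)). Methylsulfonyl and carbamoyl on the amine nitrogen are not told apart by this read-out (a number 0.10 log units lower from compound 3 to compound 4 (within the scatter)), so the two capped amino groups read alike here. Phenyl in compound 2 now stands beyond the scatter of all three other groups, including methanesulfonamido (a number 0.70 log units higher from compound 2 to compound 4 (beyond the scatter)), which leaves it the only group of the four set apart.

Open, as far as these compounds go, is whether a free amine, a carboxylic acid or a benzyl group on the same carbon would stay level with methyl or fall with phenyl. No measurement shown accounts for the level readings of methyl, ureido and methanesulfonamido.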